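A few compounds are considered here, and "the series" means these few. Any claim that something is new, unique, unknown or untested is made for them only; others in the source may bear on it.

Compound 1 `Cn1c(=O)c(=O)n(C2CCCC2)c2nc(N/N=C/c3ccco3)ncc21` is the starting point of this short series, which shares one core and varies only the aromatic group attached to the carbon with a double bond to nitrogen. In a functional assay on A549 cells (Homo sapiens) for antiproliferative activity, read by MTT assay (on this read-out higher numbers stand for weaker inhibition and lower numbers for stronger inhibition), compound 1 gives no number but only a limit, > 100000 nM, so its true value is not known; this is the limit (the limit of > 100000 nM in this assay, at which 1 of the 3 values shown sits). Compound 2 `Cn1c(=O)c(=O)n(C2CCCC2)c2nc(N/N=C/c3ccc(F)cc3Cl)ncc21`, which carries a 2-chloro-4-fluorophenyl group there, gives 11000 nM in this assay. Compound 3 `Cc1ccc(/C=N/Nc2ncc3c(n2)n(C2CCCC2)c(=O)c(=O)n3C)cc1C`, with a 3,4-dimethylphenyl group, gives 30200 nM in this assay. Both replacements lower the number, with an at least 9.0-fold lower number from compound 1 to compound 2 (0.95 log units; beyond the scatter) and an at least 3.3-fold lower number from compound 1 to compound 3 (0.51 log units; beyond the scatter), and compound 2 comes out lower than compound 3 by a 2.7-fold higher number from compound 2 to compound 3 (0.44 log units; beyond the scatter).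

Compound 4 `Cn1c(=O)c(=O)n(C2CCCC2)c2nc(N/N=C/c3cc([N+](=O)[O-])ccc3Cl)ncc21` is not yet measured. It differs from compound 1 in one place, (2-chloro-5-nitrophenyl in place of furan-2-yl on a carbon with a double bond to nitrogen). Like compound 2, it carries a chlorine on the six-membered ring, and both measured steps that swap the furan-2-yl for a substituted phenyl lowered the number beyond the scatter. A step of similar size in this assay is therefore expected, with compound 4 estimated at 15000 nM, between 5000 nM and 60000 nM. This estimate means an at least 6.6-fold lower number from compound 1 to compound 4 (0.82 log units; beyond the scatter) is expected.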

Compound 4, half-maximal inhibitory concentration: 8780 nM
Compound 4: the middle estimate sits 1.7-fold (0.23 log units) above what was measured, within the range that was stated.
By their numbers in this assay, from the lowest: compounds 4 and 2 (each within the scatter of the next); then compound 3. At a limit, above all of these: compound 1.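

In this assay, going by these compounds alone, the move from furan-2-yl to 2-chloro-5-nitrophenyl gives an at least 11-fold lower number from compound 1 to compound 4 (1.05 log units; beyond the scatter), the first step graded as large. Within the data shown here, a second chlorine-bearing phenyl also behaves much like the first, with a 1.3-fold lower number from compound 2 to compound 4 (0.10 log units; within the scatter), so at this place on the carbon with a double bond to nitrogen, the 2-chloro-4-fluorophenyl and 2-chloro-5-nitrophenyl groups cannot be told apart, while a 3.4-fold lower number from compound 3 to compound 4 (0.54 log units; beyond the scatter) places compound 3, which has no chlorine, above both chlorine-bearing compounds on the scale of numbers, although these are only two examples. Compound 1 has only a limit, so the true size of any step from it stays unknown: the limit of > 100000 nM in this assay, at which 1 of the 4 values shown sits.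

A plain phenyl, or a phenyl carrying only a chlorine or only a nitro group, would show which part of these substituted rings goes with the lower numbers. Also open is how an amine or a carboxylic acid on the ring would behave, and what changes in the shared core, which stays the same in all the compounds shown, would do.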